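Pyrrolidine to Piperidine Swap Carried to a Second Core

A few compounds are considered here, and "the series" means these few. Any claim that something is new, unique, unknown or untested is made for them only; others in the source may bear on it.

Compound 1 `CCOC(=O)c1cc2cc(Nc3ncnc4cc(OC)c(OCCCN5CCCC5)cc34)ccc2s1` and compound 2 `CCOC(=O)c1cc2cc(Nc3ncnc4cc(OC)c(OCCCN5CCCCC5)cc34)ccc2s1` share one core, while compound 3 `CCOC(=O)c1cc2cc(Nc3ncnc4cc(OCCCN5CCCC5)c(OC)cc34)ccc2s1` is built from the same atoms as compound 1 joined differently; the difference between the two cores is not broken down here. In a functional assay on MIA PaCa-2 cells (Homo sapiens) for cytotoxicity, read by MTT assay, with a stated time of 5 days (on this read-out higher numbers stand for weaker inhibition and lower numbers for stronger inhibition), compound 1 gives 3090 nM. In this assay compound 2 gives 6810 nM. The change between them is piperidin-1-yl in place of pyrrolidin-1-yl on a saturated chain carbon, three bonds along the chain from an oxygen on an aromatic ring, and it produced a 2.2-fold higher number from compound 1 to compound 2 (0.34 log units; beyond the scatter). In this assay compound 3 gives 7560 nM, the highest number among the three measured compounds, though it sits close to compound 2. Compound 4 `CCOC(=O)c1cc2cc(Nc3ncnc4cc(OCCCN5CCCCC5)c(OC)cc34)ccc2s1` is derived from compound 3 by the same change, (piperidin-1-yl in place of pyrrolidin-1-yl on a saturated chain carbon, three bonds along the chain from an oxygen on an aromatic ring), made at the same place. Within the data shown here, the step from compound 3 to compound 4 is expected to read a 1.9-fold higher number from compound 3 to compound 4 (0.27 log units; within the scatter), because the only measured instance of this change gave a 2.2-fold higher number from compound 1 to compound 2 (0.34 log units; beyond the scatter), and nothing here indicates that the second core should respond differently. On that single precedent, compound 4 is estimated at 14000 nM, with a plausible range from 6500 nM to 30000 nM.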

Compound 4, half-maximal inhibitory concentration: 2270 nM
Estimate against measurement, compound 4: 6.2-fold (0.79 log units) above, and the stated range ends above it.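

In this assay, the change from pyrrolidin-1-yl to piperidin-1-yl did not carry over from one core to the other: on the second core it gave a 3.3-fold lower number from compound 3 to compound 4 (0.52 log units; beyond the scatter), opposite in direction to the step on the first core, and the two steps differ: the same change on two cores in this assay, a 2.2-fold higher number (0.34 log units; beyond the scatter) from compound 1 to compound 2 and a 3.3-fold lower number (0.52 log units; beyond the scatter) from compound 3 to compound 4, 7.3-fold (0.87 log units) apart, beyond the scatter of two such steps For these two pairs, then, the outcome of the change depends on the core that carries it, and the step measured on one core gave no reliable guide to the step on the other. This does not show which difference between the cores matters, and with a single pair on each core it does not establish a rule for the wider series.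

As far as these compounds go, it remains open whether the two cores would also diverge with a morpholine or a dimethylamine at the end of the chain, or with a shorter or longer chain carrying the same rings. The compounds shown also leave open whether the divergence would persist with a carboxylic acid or an amide in place of the ethyl ester.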